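Methoxy for amino on the carbonyl-side ring: compound 2 to 4

The source may hold more compounds than are shown below. What is called first, only, known or untested is meant among the compounds shown, and "the series" means these compounds.

Measured compounds:
compound 1 `COc1ccc(-c2cc(/C=C/C(=O)c3ccc(N)cc3)[nH]n2)cc1`: -81%
compound 2 `COc1cc(-c2cc(/C=C/C(=O)c3ccc(N)cc3)[nH]n2)cc(OC)c1OC`: -83%
compound 3 `COc1cc(-c2cc(/C=C/C(=O)c3ccc(Cl)c(Cl)c3)[nH]n2)cc(OC)c1OC`: -16%

In a functional assay on SK-MEL-28 cells (Homo sapiens) for cytotoxicity, read by sulforhodamine B assay, with a stated time of 48 h, tested at 100 uM (a lower number here means a stronger effect, a higher number a weaker effect of the compound at the concentration tested), compound 2 stands at the lowest of the three numbers. Compound 1 sits within the scatter of it, so no order between those two can be read; compound 3 sits far higher, beyond the scatter. Compound 4 `COc1ccc(C(=O)/C=C/c2cc(-c3cc(OC)c(OC)c(OC)c3)n[nH]2)cc1` differs from compound 2 by methoxy in place of amino on an aromatic carbon.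

For the measured compounds named here, only one measured step touches the same ring: a number 67 percentage points higher from compound 2 to compound 3 (beyond the scatter). Going by the values given here, that step shows that exchanging the 4-aminophenyl on the carbonyl carbon can move this assay a long way upward, but it exchanges it for a different group than the methoxy entering here, and no step with methoxy in that place has been measured. For compound 4 a step upward in this assay is therefore expected, with an uncertain size, given as a number 38 percentage points higher from compound 2 to compound 4 (beyond the scatter). Compound 4 is thus estimated at -45%, within -85% to 0%.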

Compound 4, a percentage reported as activity, at one concentration (the size of the read-out at that concentration, not a potency): -87%
Beside the measured number, compound 4's estimate is 42 percentage points above it; the measured number lies below the stated range.
By their numbers in this assay, from the lowest: compounds 4, 2 and 1 (each within the scatter of the next); then compound 3.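

In this assay, methoxy in place of amino on this aromatic carbon leaves the read-out within the scatter (a number 4 percentage points lower from compound 2 to compound 4 (within the scatter)), so the activity of the series at this concentration does not depend on an amino group at this position, and the hydrogen-bond donor that leaves with it is not required here. The loss seen with compound 3 therefore does not follow from removing the amino group alone: with the 4-methoxyphenyl group, the read-out stays far from that of the 3,4-dichlorophenyl group (a number 71 percentage points lower from compound 3 to compound 4 (beyond the scatter)). These are readings at one concentration, so they show no potency order between the 4-aminophenyl and 4-methoxyphenyl compounds.

On these data alone, it remains open whether a hydroxyl, a dimethylamino group or a carboxylic acid at this position would read the same, and whether a single chlorine would act as the 3,4-dichlorophenyl group does. No supporting evidence accounts for these differences.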